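Working notes: compound 2 to compound 3, methoxy removed

The compounds below may be only part of what the source reports. "The series", "measured", "known", "first", "only" and "open" are said of these compounds alone.

Compound 1 `CC(C)N(C(=S)SCc1oc2ccccc2c(=O)c1Cl)C(C)C` — in a functional assay on MCF7 cells (Homo sapiens) for antiproliferative activity, read by MTT assay, with a stated time of 72 h (on this read-out higher numbers stand for weaker inhibition and lower numbers for stronger inhibition), compound 1 gives > 40000 nM, which is a limit of the assay.
Compound 2 `COc1ccc2oc(CSC(=S)N(C(C)C)C(C)C)cc(=O)c2c1` — in this assay compound 2 gives > 25000 nM, which is a limit of the assay.

Where compound 2 stands: only a limit is known for it, so its place among the numbers cannot be fixed; the other value, for compound 1, is also a limit (the limit of > 40000 nM in this assay, at which 1 of the 2 values shown sits), and compound 2 sits at the limit of > 25000 nM in this assay, at which 1 of the 2 values shown sits. Neither compound shows a measurable value, and nothing here separates the two.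

Compound 3 `CC(C)N(C(=S)SCc1cc(=O)c2ccccc2o1)C(C)C` differs from compound 2 by hydrogen in place of methoxy on an aromatic carbon; in words, hydrogen in place of methoxy on an aromatic carbon, meta to a fused ring and para to a fused ring. Among the measured compounds shown here, no measured step between these compounds exists, so no size of effect can be read from the data. The expected step from compound 2 to compound 3 is none beyond the scatter, given that compound 2 sits at a limit of this assay (the limit of > 25000 nM in this assay, at which 1 of the 2 values shown sits).

The estimate for compound 3 in this assay is 35000 nM, range 10000 nM to 100000 nM, with a limit the more likely outcome. The estimated step is a step that the limit leaves unreadable from compound 2 to compound 3.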

Compound 3, half-maximal inhibitory concentration: 31700 nM
Beside the measured number, compound 3's estimate is 1.1-fold (0.04 log units) above it; the measured number falls inside the stated range.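

In this assay, among the compounds shown here, compound 3, which carries neither chloro nor methoxy, gives the first value that is not a limit, 31700 nM. Hydrogen in place of chloro on an aromatic carbon gives an at least 1.2-fold lower number from compound 1 to compound 3 (0.10 log units; that floor lies within the scatter), so only a floor is known, and it does not establish a change at that position. The step for hydrogen in place of methoxy, on the aromatic carbon meta to a fused ring and para to a fused ring, cannot be read, because compound 2 sits at a limit: the limit of > 25000 nM in this assay, at which 1 of the 3 values shown sits.

As far as these compounds go, it remains open whether an amine or a carboxylic acid on the aromatic carbon that carries methoxy in compound 2 would give a number clearly lower than that of compound 3. Also open, from the compounds shown here alone, are the true distances of compound 1 and compound 2 from compound 3 in this assay, and with them whether chloro or methoxy changes the read-out at all.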